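This account rests on a few compounds, and the source may have more. Where it says the series, first, only, none or still open, it means among the compounds named here.

Compounds measured in a physicochemical assay for solubility; a lower number here means a less soluble compound, a higher number a more soluble compound:
compound 1 `O=C(CN1CCCC1)N1CCC(NS(=O)(=O)c2cc(S(=O)(=O)c3ccccc3)ccc2C(F)(F)F)CC1` — 25000 nM
compound 2 `CC(C)(C)OC(=O)N1CCC[C@@H]1C(=O)N1CCC(NS(=O)(=O)c2cc(S(=O)(=O)c3ccccc3)ccc2C(F)(F)F)CC1` — 25000 nM
compound 3 `CN(C)CC(=O)N1CCC[C@H]1C(=O)N1CCC(NS(=O)(=O)c2cc(S(=O)(=O)c3ccccc3)ccc2C(F)(F)F)CC1` — 100000 nM

Compound 2 sits level with compound 1 at the digits shown; together they give the two lowest numbers of the three, and compound 3 lies higher, a 4.0-fold higher number from compound 2 to compound 3 (0.60 log units; beyond the scatter). Compound 4 `O=C([C@@H]1CCCN1Cc1ccccc1)N1CCC(NS(=O)(=O)c2cc(S(=O)(=O)c3ccccc3)ccc2C(F)(F)F)CC1` is not yet measured. The change from compound 2 is: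
1-benzylpyrrolidin-2-yl in place of 1-(tert-butoxycarbonyl)pyrrolidin-2-yl on a carbonyl carbon
Among the compounds with values here, no measured step exchanges this same pair of groups. The nearest comparison is a 4.0-fold higher number from compound 2 to compound 3 (0.60 log units; beyond the scatter), where the same leaving group gave way to a different entering group; also relevant is no change at the digits printed from compound 1 to compound 2 (within the scatter). Nothing measured speaks directly for the benzyl group, so a change of at most the same order, or none beyond the scatter, is expected. Compound 4 is estimated at 30000 nM, range 10000 nM to 90000 nM. For compound 4 this estimate means an expected step of a 1.2-fold higher number from compound 2 to compound 4 (0.08 log units; within the scatter).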

Compound 4, solubility: 25000 nM
The estimate for compound 4 lay 1.2-fold (0.08 log units) above the measured number; the range from low to high includes it.
By their numbers in this assay, from the lowest: compounds 1, 2 and 4 (each within the scatter of the next); then compound 3.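

Working in this assay, 1-benzylpyrrolidin-2-yl in place of 1-(tert-butoxycarbonyl)pyrrolidin-2-yl on a carbonyl carbon gives no step beyond the scatter (no change at the digits printed from compound 2 to compound 4 (within the scatter)), and the same holds against (pyrrolidin-1-yl)methyl (no change at the digits printed from compound 1 to compound 4 (within the scatter)). Benzyl in place of ((dimethylamino)methyl)carbonyl on an amine nitrogen in a ring gives the only step here beyond the scatter (a 4.0-fold lower number from compound 3 to compound 4 (0.60 log units; beyond the scatter)), leaving compound 3 alone at the higher number. No evidence bears on what lies behind these steps.

Open, as far as these compounds go, is where an acetyl group or a carboxylic acid on that ring nitrogen would fall, level with compound 4 or nearer compound 3.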